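Methoxy to Methylamino on a Carbonyl of a Shared Core

The compounds below may be only part of what the source reports. "The series", "measured", "known", "first", "only" and "open" are said of these compounds alone.

The measured compounds, each tested in a functional assay on HepG2 cells (Homo sapiens) for antiproliferative activity, read by MTT assay, with a stated time of 72 h; on this read-out higher numbers stand for an effect only at larger amounts of compound and lower numbers for an effect already at smaller amounts:
Compound 1 `COC(=O)c1cc2cc(NCc3cc(NC(=O)c4cncc(C(F)(F)F)c4)ccc3C)cnc2[nH]1` gives 963 nM.
Compound 2 `COC(=O)c1cc2cc(NCc3cc(NC(=O)c4ccc(CN5CCC(N(C)C)C5)c(C(F)(F)F)c4)ccc3C)cnc2[nH]1` gives 673 nM.
Compound 3 `CNC(=O)c1cc2cc(NCc3cc(NC(=O)c4ccc(CN5CCN(C)CC5)cc4)ccc3C)cnc2[nH]1` gives only a limit, > 1000 nM.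

Among the two numbers actually reported in this assay, compound 2 has the lower one, but its gap to compound 1 lies within the usual scatter of this kind of measurement, so the two cannot be ranked. The reading for compound 3 is a limit of the assay and not a number (the limit of > 1000 nM in this assay, at which 1 of the 3 values shown sits).

Compound 4 `CNC(=O)c1cc2cc(NCc3cc(NC(=O)c4ccc(CN5CCC(N(C)C)C5)c(C(F)(F)F)c4)ccc3C)cnc2[nH]1` is compound 2 altered at one point: methylamino in place of methoxy on a carbonyl carbon. Going by the values given here, no pair of measured compounds differs only in this way, so the size of this step is not known from the data; compound 3 also carries methylcarbamoyl, but it differs from compound 2 elsewhere as well, so it does not isolate the change.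

With that caution, the step from compound 2 to compound 4 is expected to be small, a 1.3-fold higher number from compound 2 to compound 4 (0.13 log units; within the scatter), possibly a modest rise. Compound 4 is therefore estimated at 900 nM, within a range from 350 nM to 2500 nM.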

Compound 4, half-maximal effective concentration: 179 nM
Beside the measured number, compound 4's estimate is 5.0-fold (0.70 log units) above it; the measured number lies below the stated range.
By their numbers in this assay, from the lowest: compound 4; then compounds 2 and 1 (each within the scatter of the next). At a limit, above all of these: compound 3.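

Exchanging methoxy for methylamino on a carbonyl carbon, with the rest of the structure unchanged, gives a 3.8-fold lower number from compound 2 to compound 4 (0.58 log units; beyond the scatter) in this assay and is the first direct measure of this change among the compounds shown. The exchange leaves the count of heavy atoms the same and replaces a hydrogen-bond acceptor with a hydrogen-bond donor, yet it moves the number beyond the scatter, so this place on the shared core is sensitive to even a small change. Nothing shown here ties that shift to a measured property.

Compound 3 also carries methylcarbamoyl but differs elsewhere as well, and its reading of > 1000 nM is a limit of the assay and not a number. On these data alone, whether the same step holds with other side chains remains open, as does the outcome with a primary amide, a dimethylamide or a carboxylic acid at this carbonyl carbon.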